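The source may hold more compounds than are shown below. What is called first, only, known or untested is meant among the compounds shown, and "the series" means these compounds.

Measured compounds:
Compound 1 `O=C(c1ccc(NCc2cncn2Cc2ccc(-c3ccccc3)cc2)cc1-c1ccccc1)N1CCCCC1`; in a toxicity assay on NIH3T3 cells (Mus musculus) for cytotoxicity, read by resazurin assay (a higher number here means that more compound is needed for the effect, a lower number that less compound is needed), compound 1 gives > 1000 nM, a limit of the assay.
Compound 2 `N#Cc1ccc(NCc2cncn2Cc2ccc(-c3ccccc3)cc2)cc1-c1ccccc1`; in this assay compound 2 gives > 1000 nM, again a limit.
Compound 3 `CN(C)C(=O)c1ccc(NCc2cncn2Cc2ccc(-c3ccccc3)cc2)cc1-c1ccccc1`; in this assay compound 3 gives > 1000 nM, also a limit.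

Compound 3 thus stands at the limit of > 1000 nM in this assay, at which 3 of the 3 values shown sit, alongside both other compounds. The three measured steps, a step that the two limits leave unreadable from compound 1 to compound 2, a step that the two limits leave unreadable from compound 1 to compound 3 and a step that the two limits leave unreadable from compound 2 to compound 3, give no readable size.

Compound 4 `CN(C)c1ccc(NCc2cncn2Cc2ccc(-c3ccccc3)cc2)cc1-c1ccccc1` is the next compound; change from compound 3: dimethylamino in place of dimethylcarbamoyl on an aromatic carbon.

The steps from compound 1 and compound 2 to compound 3 touch the same position, yet each is unreadable. No step beyond the scatter is expected; compound 4 is estimated to remain at the limit, so that a step that the limit leaves unreadable from compound 3 to compound 4 is expected to be flat. Compound 4 is therefore estimated at 3000 nM, with a range of 1000 nM to 15000 nM.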

Compound 4, half-maximal effective concentration: > 1000 nM
Compound 4: only a limit was reported; the forecaster's own chance of this, stated with the estimate: 80%; the middle value lies beyond the limit too.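

The steps from compound 1, compound 2 and compound 3 to compound 4 cannot be read, as all four values are limits: the limit of > 1000 nM in this assay, at which 4 of the 4 values shown sit. Going by these compounds, the concentration at which any of these four compounds takes effect in this assay remains open, as does whether the groups exchanged here differ at all.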